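A few compounds are considered here, and "the series" means these few. Any claim that something is new, unique, unknown or untested is made for them only; others in the source may bear on it.

In a functional assay on aorta for antagonist activity at Alpha-1D adrenergic receptor (Rattus norvegicus) (a higher number here means weaker binding, a lower number tighter binding), three compounds have been measured:

Compound 1, `COc1ccccc1N1CCN(CCCNc2ncccc2C(=O)NC(C)(C)C)CC1`: 10 nM
Compound 2, `COc1ccccc1N1CCN(CCCNc2ncccc2C(=O)N(C)C)CC1`: 20 nM
Compound 3, `COc1ccccc1N1CCN(CCCNc2ncc(C#N)cc2C(=O)N(C)C)CC1`: 20 nM

Compound 2 stands level with compound 3 at the digits shown, the two together the highest of the three numbers, while compound 1 sits nearest below. Both recorded steps, a 2.0-fold higher number from compound 1 to compound 2 (0.30 log units; within the scatter) and no change at the digits printed from compound 2 to compound 3 (within the scatter), lie within the scatter, so the amide and the pyridine substituent have moved the readout little. Compound 4, `COc1ccc(N2CCN(CCCNc3ncccc3C(=O)N(C)C)CC2)c(OC)c1`, differs from compound 2 by methoxy in place of hydrogen on an aromatic carbon. Within the data shown here, no measured step touches the aromatic ring of carbon only, so the two steps bear only loosely on this change; as both were flat, compound 4 is expected to show no change at the digits printed from compound 2 to compound 4 (within the scatter), with an estimate of 20 nM between 7 nM and 60 nM.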

Compound 4, dissociation constant: 1000 nM
Beside the measured number, compound 4's estimate is 50-fold (1.70 log units) below it, outside the stated range (above it).
By their numbers in this assay, from the lowest: compounds 1, 2 and 3 (each within the scatter of the next); then compound 4.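

In this assay, the change from 2-methoxyphenyl to 2,4-dimethoxyphenyl gives a 50-fold higher number from compound 2 to compound 4 (1.70 log units; beyond the scatter), the only step shown that lies beyond the scatter. Among these compounds, this position on the aromatic ring of carbon only, para to a large group, therefore responds strongly to methoxy in place of hydrogen, unlike the places changed in the earlier steps. Nothing available explains this large step.

As far as these compounds go, whether a smaller group such as fluorine or methyl would be tolerated at this position remains open. So does whether methoxy has the same effect in compound 1 or compound 3.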